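Quinoline chalcones: a thiophene in place of a pyridine

The compounds below may be only part of what the source reports. "The series", "measured", "known", "first", "only" and "open" are said of these compounds alone.

Measured compounds:
compound 1 `COc1ccc(-c2cc3ccccc3nc2/C=C/C(=O)c2ccc(N)cc2)cc1` gives 9290 nM in a functional assay on H184B5F5/M10 cells (Homo sapiens) for antiproliferative activity, read by XTT assay, with a stated time of 72 h; on this read-out higher numbers stand for weaker inhibition and lower numbers for stronger inhibition
compound 2 `COc1ccc(-c2cc3ccccc3nc2/C=C/C(=O)c2ccccn2)cc1` gives 4140 nM in this assay

Compound 2 stands lowest of the two numbers shown; its nearest neighbour is compound 1, and the step of a 2.2-fold lower number from compound 1 to compound 2 (0.35 log units; beyond the scatter) lies beyond the scatter. Compound 3 `COc1ccc(-c2cc3ccccc3nc2/C=C/C(=O)c2ccsc2)cc1` has not yet been measured. It differs from compound 2 by thiophen-3-yl in place of pyridin-2-yl on a carbonyl carbon. For the measured compounds named here, the only measured step touches the same place, the group on the carbonyl carbon, and was modest; nothing measured shows a thiophen-3-yl there, so that step bears on compound 3 only loosely. A step of at most similar size, in either direction or none beyond the scatter, is therefore expected. Compound 3 is estimated at 4500 nM, with a range from 1500 nM to 14000 nM, which means an expected step of a 1.1-fold higher number from compound 2 to compound 3 (0.04 log units; within the scatter).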

Compound 3, half-maximal inhibitory concentration: 6390 nM
Compound 3: the middle estimate sits 1.4-fold (0.15 log units) below what was measured, within the range that was stated.
By their numbers in this assay, from the lowest: compounds 2, 3 and 1 (each within the scatter of the next, the first and the last beyond it).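

In this assay, thiophen-3-yl on the carbonyl carbon gives a number that cannot be told apart from that of either group seen there before (a 1.5-fold higher number from compound 2 to compound 3 (0.19 log units; within the scatter); a 1.5-fold lower number from compound 1 to compound 3 (0.16 log units; within the scatter)). The position therefore tolerates a five-membered aromatic ring with sulfur as its hetero atom in place of pyridin-2-yl, and compound 3 cannot be ranked against compound 1 or compound 2, although those two are separated by a step beyond the scatter. Nothing available explains these numbers.

On these data alone, whether thiophen-2-yl, furan-3-yl, an unsubstituted phenyl or a carboxylic acid on the carbonyl carbon would read differently remains open. As far as these compounds go, the shared core is the same in all three compounds, so the effect of a change elsewhere on it also remains open.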